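A Fluorine Added to the Phenyl of Compound 1

The source may report more compounds than this note shows. Statements on the series, on what has been measured and on what is new or still open speak of the compounds shown alone.

Of the compounds shown here, two have been measured in an assay on cell membranes for displacement of a labelled ligand from Cholecystokinin receptor type A (Rattus norvegicus), read by radioligand binding; on this read-out lower numbers stand for stronger inhibition and higher numbers for weaker inhibition. Compound 1, `O=C(N[C@@H]1C(=O)N(c2ccccc2)C[C@@H]1C(=O)O)c1ccc2ccccc2c1`, gives 16 nM in this assay. Compound 2, `O=C(N[C@H]1C(=O)N(c2ccccc2)C[C@@H]1C(=O)O)c1ccc2ccccc2c1`, has the same atoms and bonds and differs only in the configuration at one saturated ring carbon; in this assay compound 2 gives 290 nM. That change alone produced an 18-fold higher number from compound 1 to compound 2 (1.26 log units; beyond the scatter), a shift that rests on (the fact that compounds 1 and 2 differ only in the configuration as drawn). On the numbers shown, compound 1 thus stands lowest of the two, with compound 2 as its only neighbour.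

Compound 3, `O=C(N[C@@H]1C(=O)N(c2ccccc2F)C[C@@H]1C(=O)O)c1ccc2ccccc2c1`, has not yet been measured. It differs from compound 1 in a single place: fluoro in place of hydrogen on an aromatic carbon. Among the measured compounds shown here, the only measured step concerns configuration at a ring carbon and not a substituent on the phenyl, so no measured step bears on this change. With nothing pointing to a gain or a loss, the expectation for compound 3 is no step beyond the usual scatter, that is no change at the digits printed from compound 1 to compound 3 (within the scatter). Compound 3 is therefore estimated at 16 nM, with a likely range from 5 nM to 50 nM.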

Compound 3, half-maximal inhibitory concentration: 62 nM
Compound 3: the middle estimate sits 3.9-fold (0.59 log units) below what was measured, and the stated range ends below it.
By their numbers in this assay, from the lowest: compound 1; then compound 3; then compound 2.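

Fluoro in place of hydrogen on the phenyl, ortho to a large group, gives a 3.9-fold higher number from compound 1 to compound 3 (0.59 log units; beyond the scatter) in this assay, so this position does not tolerate every change without a shift. Among the compounds shown here, until now the only measured step lay in the configuration at a ring carbon, and this is the first sign that the number also responds to a change on the phenyl, even one that adds a single heavy atom and no ring, hydrogen-bond donor, hydrogen-bond acceptor or charge. The step is modest but beyond the scatter, and nothing measured here explains why the number rises with this change.

The compounds shown leave open whether another group at this same place, such as chloro, methyl or methoxy, would give a number closer to that of compound 1 or further from it, and whether the shift belongs to fluoro itself or to the place it occupies. On these data alone, it also remains open whether the same fluoro on the phenyl of compound 2 would move the number in the same direction.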